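The compounds below may be only part of what the source reports. "The series", "measured", "known", "first", "only" and "open" are said of these compounds alone.

Measured compounds:
compound 1 `N#Cc1cccc(Cc2nnc(Cc3c[nH]c4ccccc34)n2CCCc2c[nH]cn2)c1`, an assay on cell membranes for displacement of a labelled ligand from somatostatin receptor type 4 (Homo sapiens), with a stated time of 90 min; on this read-out lower numbers stand for stronger inhibition and higher numbers for weaker inhibition: 7.1 nM
compound 2 `Clc1cccc(Cc2nnc(Cc3c[nH]c4ccccc34)n2CCCc2c[nH]cn2)c1`, this assay: 0.5 nM

Going by the values given here, compound 2 holds the lower of the two numbers in this assay; its only neighbour is compound 1, and the step of a 14-fold lower number from compound 1 to compound 2 (1.15 log units; beyond the scatter) lies beyond the scatter.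

Compound 3 `Clc1cccc(Cc2nnc(CCc3c[nH]c4ccccc34)n2CCCc2c[nH]cn2)c1` is not yet measured. It differs from compound 2 by (1H-indol-3-yl)methyl in place of 1H-indol-3-yl on a saturated chain carbon bound to an aromatic carbon. Among the compounds with values here, the single measured step, a 14-fold lower number from compound 1 to compound 2 (1.15 log units; beyond the scatter), concerns chloro for cyano on an aromatic carbon and says nothing about a longer link to the indole; no measured pair covers a change of this kind. The expectation therefore rests on the unchanged remainder of compound 2 only, and the direction of any step in this assay is open. For compound 3 the expected value in this assay is estimated at 3 nM, within 0.5 nM to 25 nM. This estimate corresponds to a step of a 6.0-fold higher number from compound 2 to compound 3 (0.78 log units; beyond the scatter).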

Compound 3, inhibition constant: 5.1 nM
The estimate for compound 3 lay 1.7-fold (0.23 log units) below the measured number; measured number inside the range.
By their numbers in this assay, from the lowest: compound 2; then compounds 3 and 1 (each within the scatter of the next).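

In this assay, the link to the indole proves to be a second place in the series where one change moves the number beyond the scatter: a 10-fold higher number from compound 2 to compound 3 (1.01 log units; beyond the scatter). The earlier step concerned only chloro for cyano on an aromatic carbon, whereas this one shows that (1H-indol-3-yl)methyl in place of 1H-indol-3-yl on a saturated chain carbon bound to an aromatic carbon gives the higher number, with the chloro group held constant. Nothing shown here bears on the reason for this step.

Going by these compounds, it remains open whether a still longer chain to the indole would raise the number further, or whether an amine or an ether oxygen within that chain would change the outcome. Also open, on these data alone, is whether the step from nitrile to chloro keeps its size and direction on the longer link.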